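Removing a methyl from a quinolinone hydrazone scaffold

The source may hold more compounds than are shown below. What is called first, only, known or untested is meant among the compounds shown, and "the series" means these compounds.

The measured compounds in a functional assay, read by spectrophotometry, with a stated time of 5 min (a lower number here means a stronger inhibitor, a higher number a weaker inhibitor), are these. Compound 1, `NS(=O)(=O)CC(=O)N/N=C/c1cc2ccccc2[nH]c1=O`, gives 256000 nM. Compound 2, `O=c1[nH]c2ccccc2cc1/C=N/Nc1ccc([N+](=O)[O-])cc1`, gives "not active" (no number reported). Compound 3, `Cc1ccc2[nH]c(=O)c(/C=N/Nc3ccccc3)cc2c1`, gives 309000 nM.

For the measured compounds named here, only two of the three compounds give a number in this assay. The number for compound 3 and the number for compound 1 lie within the usual scatter of each other, so no order can be read between them, while compound 2 gives no number at all. All three share the same core, and the measured values do not separate the hydrazone substituents from one another.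

Compound 4, `O=c1[nH]c2ccccc2cc1/C=N/Nc1ccccc1`, is not yet measured. It differs from compound 3 in one place: hydrogen in place of methyl on an aromatic carbon. Going by the values given here, no step between measured compounds bears on this change, so there is nothing to suggest a direction. The expected step from compound 3 to compound 4 in this assay is a 1.0-fold lower number from compound 3 to compound 4 (0.01 log units; within the scatter), that is, none beyond the scatter. Compound 4 is therefore estimated at 300000 nM, with a range from 120000 nM to 750000 nM.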

Compound 4, half-maximal inhibitory concentration: 306000 nM
For compound 4 the middle estimate is 1.0-fold (0.01 log units) below the measured one; the range from low to high includes it.
By their numbers in this assay, from the lowest: compounds 1, 4 and 3 (each within the scatter of the next).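

In this assay, for the compounds shown here, hydrogen in place of methyl on an aromatic carbon, meta to a fused ring and para to a fused ring, gives a 1.0-fold lower number from compound 3 to compound 4 (0.00 log units; within the scatter) and thus provides the first reading at this position: the methyl can be absent with no change beyond the scatter. Going by these compounds alone, compound 4 also provides a first step on the amine nitrogen, where phenyl in place of (sulfamoylmethyl)carbonyl gives a 1.2-fold higher number from compound 1 to compound 4 (0.08 log units; within the scatter) and so does not separate these two groups either. Nothing shown here offers an explanation for either result.

Going by these compounds, whether an amine or a carboxylic acid on this aromatic carbon would move the number beyond the scatter remains open. On these data alone, it is equally open whether a methoxy group or a chlorine atom there would do so.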